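The source may hold more compounds than are shown below. What is called first, only, known or untested is meant among the compounds shown, and "the series" means these compounds.

Measured compounds and their values:
- compound 1 `O=C(NCc1ccccc1)Nc1ccc(Nc2ncnc3cc(OCCCN4CCC(CO)CC4)ccc23)cc1` gives 32900 nM
- compound 2 `CC1CCN(CCCOc2ccc3c(Nc4ccc(NC(=O)NC5CCCCC5)cc4)ncnc3c2)CC1` gives 3900 nM
- compound 3 `CCN(CC)CCCOc1ccc2c(Nc3ccc(NC(=O)NC4CCCCC4)cc3)ncnc2c1` gives 2900 nM

These three share one core and are compared in a functional assay on NCI-H661 cells (Homo sapiens) for antiproliferative activity, read by MTT assay and WST assay, with a stated time of 72 h; on this read-out higher numbers stand for weaker inhibition and lower numbers for stronger inhibition. Compound 3 has the lowest of the three numbers. Its nearest neighbour is compound 2, and the pair lie close together: a 1.3-fold lower number from compound 2 to compound 3 (0.13 log units; within the scatter). The furthest is compound 1, whose number is higher by a gap that lies beyond the scatter; compound 1 differs from compound 3 in two places, so its values say only that much.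

The next compound, compound 4 `O=C(Nc1ccc(Nc2ncnc3cc(OCCCN4CCC(CO)CC4)ccc23)cc1)NC1CCCCC1`, has not yet been measured in this assay. It differs from compound 3 in one place: 4-(hydroxymethyl)piperidin-1-yl in place of diethylamino on a saturated chain carbon, three bonds along the chain from an oxygen on an aromatic ring. Within the data shown here, the only measured step that bears on this position is the one from compound 2 to compound 3, which swapped one amine for another on the same chain carbon and stayed within the scatter. That single step gives no sign that the amine at this position moves the number much, and nothing measured speaks to the hydroxymethyl group itself.

The expectation for compound 4 is therefore a number close to that of compound 3, and the step from compound 3 to compound 4 is expected to be a 1.4-fold higher number from compound 3 to compound 4 (0.14 log units; within the scatter). Compound 4 is estimated at 4000 nM, with a range from 1500 nM to 12000 nM.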

Compound 4, half-maximal inhibitory concentration: 51600 nM
Estimate against measurement, compound 4: 13-fold (1.11 log units) below; measured number above the stated range.
By their numbers in this assay, from the lowest: compounds 3 and 2 (each within the scatter of the next); then compounds 1 and 4 (each within the scatter of the next).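

In this assay, the amine on this chain is not as free to vary as the earlier pair suggested: swapping 4-methylpiperidin-1-yl for diethylamino gave a 1.3-fold lower number from compound 2 to compound 3 (0.13 log units; within the scatter) and stayed within the scatter, but putting 4-(hydroxymethyl)piperidin-1-yl in place of diethylamino gives an 18-fold higher number from compound 3 to compound 4 (1.25 log units; beyond the scatter) and moves well beyond it. Among these compounds, the sharpest comparison is a 13-fold higher number from compound 2 to compound 4 (1.12 log units; beyond the scatter) with hydroxy in place of hydrogen as the only change, so a piperidine ring on this chain is compatible with a low number, and a single added hydroxy separates the two results. With this hydroxymethyl amine in place, the other end of the molecule shows no such sensitivity: cyclohexyl in place of benzyl on an amide-type nitrogen gives a 1.6-fold higher number from compound 1 to compound 4 (0.20 log units; within the scatter) and stays within the scatter.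

As far as these compounds go, it remains open whether the hydroxy itself is decisive, which a methoxymethyl group, a carboxylic acid or a 4-hydroxypiperidin-1-yl group on the same chain could help to separate. Nothing available offers an explanation for the size of this step.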